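Bromo benzamide series: from compound 2 to compound 4

The compounds below may be only part of what the source reports. "The series", "measured", "known", "first", "only" and "open" are said of these compounds alone.

Measured in an ADME assay on HEK293 cells (Homo sapiens) for cytotoxicity, read by reporter gene assay and resazurin assay, with a stated time of 48 h; a lower number here means that less compound is tolerated, a higher number that more compound is tolerated:
- compound 1 `O=C(Nc1ccccc1)c1cc(Br)ccc1O`: 35000 nM
- compound 2 `COc1ccc(Br)cc1C(=O)Nc1ccc(Sc2nc3ccccc3s2)cc1`: > 100000 nM (a limit)
- compound 3 `COc1c(Br)cc(Br)cc1C(=O)Nc1cccc(Cl)c1`: > 100000 nM (a limit)

In this assay compound 2 gives > 100000 nM, which is a limit and not a number. Compound 3 also gives a limit, > 100000 nM. Both compounds stand at the limit of > 100000 nM in this assay, at which 2 of the 3 values shown sit.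

Compound 4 `O=C(Nc1ccc(Sc2nc3ccccc3s2)cc1)c1cc(Br)cc(Br)c1O` has not been measured yet. The change from compound 2 to compound 4 is 3,5-dibromo-2-hydroxyphenyl in place of 5-bromo-2-methoxyphenyl on a carbonyl carbon: 3,5-dibromo-2-hydroxyphenyl replaces 5-bromo-2-methoxyphenyl on a carbonyl carbon.

Going by the values given here, no step between measured compounds is available, so the expectation rests on single values. Among the compounds with values here, compound 1, the one measured compound with a hydroxy rather than a methoxy group, gives 35000 nM. That value of compound 1 points towards less compound being tolerated, although compound 1 also differs from compound 4 elsewhere. The expected step, which should lie beyond the scatter, is an at least 3.3-fold lower number from compound 2 to compound 4 (0.52 log units; beyond the scatter). For compound 4 the estimated value is 30000 nM, with an expected range of 9000 nM to 100000 nM.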

Compound 4, half-maximal cytotoxic concentration: 66000 nM
The estimate for compound 4 lay 2.2-fold (0.34 log units) below the measured number, and the stated range covers the measured number.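

In this assay, 3,5-dibromo-2-hydroxyphenyl in place of 5-bromo-2-methoxyphenyl on a carbonyl carbon gives an at least 1.5-fold lower number from compound 2 to compound 4 (0.18 log units; that floor lies within the scatter). Going by these compounds alone, this is the first step that can be read at this position, and with the remainder of the structure held constant, the change yields a measured number on one side, although that floor alone does not establish a change beyond the scatter. The true size of the step stays open because compound 2 stands at a limit and not at a number: the limit of > 100000 nM in this assay, at which 2 of the 4 values shown sit.

The step combines a hydroxy in place of a methoxy with an added bromine, and the compounds shown do not separate the two. From the compounds shown here alone, how an amine or a carboxylic acid in place of the hydroxy would read in this assay also remains open.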